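A Chloro Added to the Benzyl of Compound 2

This account rests on a few compounds, and the source may have more. Where it says the series, first, only, none or still open, it means among the compounds named here.

Compound 2 `Cn1c(-c2ccc(NC(=O)CN3CCN(Cc4ccccc4)CC3)cc2)nc(-c2ccccc2)c1-c1ccccc1` and compound 1 `CN(C)/C=C/N1CCN(CC(=O)Nc2ccc(-c3nc(-c4ccccc4)c(-c4ccccc4)n3C)cc2)CC1` share one core and differ only in the group on a ring nitrogen. In a functional assay on HT-29 cells (Homo sapiens) for cytotoxicity, read by MTT assay, with a stated time of 24 h, tested at 16 ug/mL (a lower number here means a weaker effect, a higher number a stronger effect of the compound at the concentration tested), compound 2 gives 37%, and compound 1 gives 28.2%; the step of a number 8.8 percentage points higher from compound 1 to compound 2 (within the scatter) tells how close these two numbers lie. Compound 3 `Cn1c(-c2ccc(NC(=O)CN3CCN(Cc4ccc(Cl)cc4)CC3)cc2)nc(-c2ccccc2)c1-c1ccccc1` carries chloro in place of hydrogen on an aromatic carbon. Among the compounds with values here, the only measured step concerns a different group, so no measured step bears on this change. The step of a number 1 percentage points higher from compound 2 to compound 3 (within the scatter) is therefore expected to stay within the scatter. Compound 3 is estimated at 38% in this assay, with a range from 25% to 52%.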

Compound 3, a percentage reported as activity, at one concentration (the size of the read-out at that concentration, not a potency): 52.9%
Compound 3: middle estimate off by 14.9 percentage points, on the low side; the measured number lies above the stated range.
By their numbers in this assay, from the lowest: compounds 1 and 2 (each within the scatter of the next); then compound 3.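

In this assay, within the data shown here, chloro in place of hydrogen on the benzyl is the first single change here to move the number beyond the scatter (a number 15.9 percentage points higher from compound 2 to compound 3 (beyond the scatter)). Placing 4-chlorobenzyl rather than 2-(dimethylamino)ethenyl on the ring nitrogen also gives a step beyond the scatter (a number 24.7 percentage points higher from compound 1 to compound 3 (beyond the scatter)), whereas plain benzyl did not. Nothing available here explains why the chloro has this effect. As far as these compounds go, it remains open whether fluoro, bromo, methyl or methoxy at this place would give a similar number, and whether chloro elsewhere on the benzyl would.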